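Pyrrolyl in place of dimethylaminophenyl at the enone terminus

The source may report more compounds than this note shows. Statements on the series, on what has been measured and on what is new or still open speak of the compounds shown alone.

Three members of the series have been measured in an ADME assay on the whole organism for cytotoxicity, with Artemia salina as the target, with a stated time of 24 h; on this read-out higher numbers stand for an effect only at larger amounts of compound and lower numbers for an effect already at smaller amounts. Compound 1 `Cc1ccc(S(=O)(=O)NC(=O)Nc2ccccc2C(=O)/C=C/c2ccccc2)cc1` gives 25 ug/mL. Compound 2 `Cc1ccc(S(=O)(=O)NC(=O)Nc2ccccc2C(=O)/C=C/c2ccc(N(C)C)cc2)cc1` gives 38.1 ug/mL, and compound 3 `Cc1ccc(S(=O)(=O)NC(=O)Nc2ccccc2C(=O)/C=C/c2ccc(Cl)cc2)cc1` gives 6.92 ug/mL. Compound 2 stands at the top of the three numbers, but the step of a 1.5-fold higher number from compound 1 to compound 2 (0.18 log units; within the scatter) is within the scatter, while a 5.5-fold lower number from compound 2 to compound 3 (0.74 log units; beyond the scatter) and a 3.6-fold lower number from compound 1 to compound 3 (0.56 log units; beyond the scatter) are beyond it.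

Compound 4 `Cc1ccc(S(=O)(=O)NC(=O)Nc2ccccc2C(=O)/C=C/c2ccc[nH]2)cc1` is not yet measured. Its difference from compound 2: 1H-pyrrol-2-yl in place of 4-(dimethylamino)phenyl on a double-bonded chain carbon bound to a double-bonded chain carbon. Going by the values given here, no measured step swaps the whole ring; the only one touching the dimethylamino group is a 1.5-fold higher number from compound 1 to compound 2 (0.18 log units; within the scatter), which lies within the scatter. The chloro steps speak to a different substituent and are not taken as a guide. In this assay the step of a 1.5-fold lower number from compound 2 to compound 4 (0.18 log units; within the scatter) is therefore expected to stay within the scatter, with no clear direction. Compound 4 is estimated at 25 ug/mL, with a range from 10 ug/mL to 60 ug/mL.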

Compound 4, concentration for half-maximal effect: 32.1 ug/mL
For compound 4 the middle estimate is 1.3-fold (0.11 log units) below the measured one; measured number inside the range.
By their numbers in this assay, from the lowest: compound 3; then compounds 1, 4 and 2 (each within the scatter of the next).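

In this assay replacing the whole ring on a double-bonded chain carbon bound to a double-bonded chain carbon leaves the number within the scatter, as shown by a 1.2-fold lower number from compound 2 to compound 4 (0.07 log units; within the scatter) and by a 1.3-fold higher number from compound 1 to compound 4 (0.11 log units; within the scatter). Thus 1H-pyrrol-2-yl, phenyl and 4-(dimethylamino)phenyl cannot be told apart here, even though 1H-pyrrol-2-yl is a five-membered ring with fewer heavy atoms than 4-(dimethylamino)phenyl and brings a hydrogen-bond donor. Only 4-chlorophenyl stands apart, with a 4.6-fold higher number from compound 3 to compound 4 (0.67 log units; beyond the scatter) adding to the earlier chloro steps, so compound 3 is separated from all three other compounds.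

Nothing shown gives a reason for these steps. Whether the low number of compound 3 is specific to chloro remains open, since neither fluoro, bromo nor a carboxylic acid in place of chloro appears among these compounds.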